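The compounds below may be only part of what the source reports. "The series", "measured", "known", "first", "only" and "open" are said of these compounds alone.

Notes on the series. In an assay on isolated protein for displacement of a labelled ligand from metabotropic glutamate receptor 5 (Homo sapiens), with a stated time of 60 min, tested at 1 uM (a higher number here means more inhibition at the concentration tested (going by the name of the read-out), a lower number less inhibition), compound 2 `Cc1ccc(S(=O)(=O)c2cnc3cc(Cl)ccc3c2N2CCC(C)CC2)cc1C` gives 86%, the second highest of the three numbers. Within the data shown here, compound 3 `Cc1ccc(S(=O)(=O)c2cnc3cc(F)ccc3c2N2CCC(C)CC2)cc1C` gives 90%, and the only single-site step available is a number 4 percentage points higher from compound 2 to compound 3 (within the scatter). Compound 1 `Cc1ccc(S(=O)(=O)c2cnc3ccc(Cl)cc3c2N2CCC(C)CC2)cc1F` gives 68%; it differs from compound 2 in two places, so its gap to compound 2 is a difference of values only, not a step. Compound 4 `COc1cccc(S(=O)(=O)c2cnc3cc(Cl)ccc3c2N2CCC(C)CC2)c1` is unmeasured and differs from compound 2 by 3-methoxyphenyl in place of 3,4-dimethylphenyl on a sulfonyl sulfur. Among the measured compounds shown here, no measured step alters the aryl group on the sulfonyl sulfur, so none bears directly on this change, and the expectation rests on compound 2 alone. For compound 4 the expected step is a number 14 percentage points lower from compound 2 to compound 4 (beyond the scatter), a modest downward lean rather than a confident shift. For compound 4 the estimate is 72%, with a range of 50% to 90%.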

Compound 4, a percentage reported as inhibition, at one concentration (the size of the read-out at that concentration, not a potency): 93%
For compound 4 the middle estimate is 21 percentage points below the measured one; measured number above the stated range.
By their numbers in this assay, from the lowest: compound 1; then compounds 2, 3 and 4 (each within the scatter of the next).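

On the sulfonyl sulfur, the change to 3-methoxyphenyl gives, in this assay, a number 7 percentage points higher from compound 2 to compound 4 (within the scatter) and so leaves the read-out within the scatter. This position therefore accepts an aryl group with a hydrogen-bond acceptor in place of 3,4-dimethylphenyl, with no loss visible at this single concentration. No measurement here offers an explanation for this result.

From the compounds shown here alone, whether an ethoxy group in place of the methoxy group would hold the read-out remains open. So does the effect of a carboxylic acid or an amine on this aryl ring.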